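A few compounds are considered here, and "the series" means these few. Any claim that something is new, unique, unknown or untested is made for them only; others in the source may bear on it.

Within the data shown here, compound 3 `N#Cc1cc(Cl)c(Nc2nc3c(Nc4ccc(C(F)(F)F)cc4)ncnc3s2)c(Cl)c1` gives 53 nM in a functional assay on HEK293 cells for antagonist activity at transient receptor potential cation channel subfamily V member 1 (Rattus norvegicus), read by calcium flux (a higher number here means a weaker inhibitor, a lower number a stronger inhibitor), the highest of the three numbers measured so far. Its nearest neighbour is compound 2 `FC(F)(F)c1ccc(Nc2ncnc3sc(Nc4ccccc4Cl)nc23)cc1`, which gives 32 nM in this assay; the step of a 1.7-fold higher number from compound 2 to compound 3 (0.22 log units; within the scatter) stays within the scatter. Furthest away is compound 1 `Cc1cccc(C)c1Nc1nc2c(Nc3ccc(C(F)(F)F)cc3)ncnc2s1`, which gives 6 nM; the steps of an 8.8-fold higher number from compound 1 to compound 3 (0.95 log units; beyond the scatter) and a 5.3-fold higher number from compound 1 to compound 2 (0.73 log units; beyond the scatter) both lie beyond the scatter. Compound 4 `OCc1cc(Cl)c(Nc2nc3c(Nc4ccc(C(F)(F)F)cc4)ncnc3s2)c(Cl)c1` differs from compound 3 by hydroxymethyl in place of cyano on an aromatic carbon, on an aromatic carbon of a six-membered aromatic ring of carbon only, meta to two chloro groups. Among the measured compounds shown here, no measured step changes a group at that place alone; the closest guide is a 1.7-fold higher number from compound 2 to compound 3 (0.22 log units; within the scatter), which brought in the cyano group together with a second chloro group and remained within the scatter. With nothing pointing to a strong effect of this swap, the step of a 1.1-fold higher number from compound 3 to compound 4 (0.05 log units; within the scatter) is expected to stay within the scatter. Compound 4 is therefore estimated at 60 nM in this assay, with a likely range from 25 nM to 150 nM.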

Compound 4, half-maximal inhibitory concentration: 0.5 nM
The estimate for compound 4 lay 120-fold (2.08 log units) above the measured number, and the stated range ends above it.
By their numbers in this assay, from the lowest: compound 4; then compound 1; then compounds 2 and 3 (each within the scatter of the next).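

In this assay, among these compounds, exchanging cyano for hydroxymethyl, meta to two chloro groups, gives the largest change seen so far (a 110-fold lower number from compound 3 to compound 4 (2.03 log units; beyond the scatter)), so this position is far more sensitive than the earlier compounds suggested. The 2,6-dichloro-4-(hydroxymethyl)phenyl group also goes beyond both the 2-chlorophenyl group (a 64-fold lower number from compound 2 to compound 4 (1.81 log units; beyond the scatter)) and the 2,6-dimethylphenyl group (a 12-fold lower number from compound 1 to compound 4 (1.08 log units; beyond the scatter)), making compound 4 the strongest inhibitor of the four. The swap adds one hydrogen-bond donor, but nothing measured here says why the number falls so far.

From the compounds shown here alone, it remains open whether the gain depends on the hydroxyl itself, which an aminomethyl group, a methoxymethyl group or a carboxylic acid at this place could show. A longer chain such as hydroxyethyl could show whether the length of the group matters too.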